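Alkyl chain shortening on the shared core: cytotoxicity notes

This account rests on a few compounds, and the source may have more. Where it says the series, first, only, none or still open, it means among the compounds named here.

Compound 1 `CCCCCCCCc1ccc(-c2cc3cn([C@H]4C[C@H](O)[C@@H](CO)O4)c(=O)nc3s2)cc1`: > 200000 nM in a functional assay on HeLa cells (Homo sapiens) for cytotoxicity; on this read-out higher numbers stand for lower toxicity in this test and lower numbers for higher toxicity in this test
Compound 2 `CCCCCCc1ccc(-c2cc3cn([C@H]4C[C@H](O)[C@@H](CO)O4)c(=O)nc3s2)cc1`: > 200000 nM in this assay
Compound 3 `CCCCCCCc1ccc(-c2cc3cn([C@H]4C[C@H](O)[C@@H](CO)O4)c(=O)nc3s2)cc1`: > 200000 nM in this assay

Each of these values is a limit of this assay and not a number. Compound 3 thus stands at that limit. All three measurements sit at the limit of > 200000 nM in this assay, at which 3 of the 3 values shown sit. Compound 4 `CCc1ccc(-c2cc3cn([C@H]4C[C@H](O)[C@@H](CO)O4)c(=O)nc3s2)cc1` differs from compound 3 by hydrogen in place of pentyl on a saturated chain carbon, two bonds along the chain from an aromatic carbon. The measured steps a step that the two limits leave unreadable from compound 1 to compound 2, a step that the two limits leave unreadable from compound 1 to compound 3 and a step that the two limits leave unreadable from compound 2 to compound 3 are all unreadable, so no size can be taken from them. Nothing in the series points to toxicity emerging on removal of the pentyl, so a step of a number no higher from compound 3 to compound 4 (the limit leaves the size open) is expected, most likely again reported as a limit. Compound 4 is estimated at 200000 nM, with a range from 100000 nM to 400000 nM, in this assay.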

Compound 4, half-maximal cytotoxic concentration: > 200000 nM
Compound 4: only a limit was reported (the forecaster's own chance of this, stated with the estimate: 85%); the middle value lies on the limit itself.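

Within the data shown here, compound 1, compound 2, compound 3 and compound 4 are all reported as limits, so no step to compound 4 can be read: the limit of > 200000 nM in this assay, at which 4 of the 4 values shown sit. The compounds shown leave open how far their true cytotoxic concentrations differ.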